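Replacing the phenyl of compound 1 with pyrrolidinylamino

The source may report more compounds than this note shows. Statements on the series, on what has been measured and on what is new or still open speak of the compounds shown alone.

Measured so far:
compound 1, `Cn1cc(-c2n[nH]c3ccc(-c4ccccc4)cc23)cn1`: 620 nM
compound 2, `Clc1cc2[nH]nc(-c3cnn(-c4ccccc4)c3)c2cc1N[C@@H]1CCNC1`: 1700 nM
compound 3, `COc1ccc(-n2cc(-c3n[nH]c4cc(Cl)c(N[C@@H]5CCNC5)cc34)cn2)cc1`: 300 nM

In an assay on isolated protein for inhibition of tyrosine-protein kinase receptor UFO (Homo sapiens), with a stated time of 1.5 h (a lower number here means a stronger inhibitor, a higher number a weaker inhibitor), compound 1 holds the second highest of the three numbers; compound 3 gives a lower number and compound 2 a higher one, both differences beyond the scatter. Compound 4, `Cn1cc(-c2n[nH]c3ccc(N[C@H]4CCNC4)cc23)cn1`, differs from compound 1 in one place: (pyrrolidin-3-yl)amino in place of phenyl on an aromatic carbon. Among the measured compounds shown here, the only measured single-place step, a 5.7-fold lower number from compound 2 to compound 3 (0.75 log units; beyond the scatter), concerns a methoxy on the phenyl attached to the pyrazole and does not touch the exchange made here. Compounds 2 and 3 both carry the entering (pyrrolidin-3-yl)amino group, but each also bears a chlorine and a different substituent on the pyrazole, so neither gives a clean reading of the phenyl to amine exchange; their numbers fall on either side of compound 1. For the measured compounds named here, with no step that bears directly on this change, the expectation for this assay is no step beyond the scatter, in either direction, with a wide range to reflect the lack of a matched pair. Compound 4 is therefore estimated at 700 nM, between 250 nM and 2000 nM, which means an expected step of a 1.1-fold higher number from compound 1 to compound 4 (0.05 log units; within the scatter).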

Compound 4, half-maximal inhibitory concentration: 239000 nM
Beside the measured number, compound 4's estimate is 340-fold (2.53 log units) below it; the whole stated range lies below it.
By their numbers in this assay, from the lowest: compound 3; then compound 1; then compound 2; then compound 4.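

In this assay, among the compounds shown here, the exchange of phenyl for (pyrrolidin-3-yl)amino on this aromatic carbon gives a 390-fold higher number from compound 1 to compound 4 (2.59 log units; beyond the scatter), the first reading of a single change at this position, and it shows that the position is far from indifferent to what it carries. The two groups are equal in heavy-atom count, so the large step comes with a change in the kind of group rather than in the number of heavy atoms: an all-carbon aromatic ring leaves, and a non-aromatic ring with a hetero atom, joined through an amino nitrogen and carrying hydrogen-bond donors and acceptors, enters. Nothing available explains the size of this step.

The compounds shown leave open whether the step follows the departure of the aromatic ring or the arrival of the amine; a cyclohexyl, a pyridyl or a phenylamino group on this carbon would help to separate the two. Also open, from the compounds shown here alone, is how the same exchange reads on a core carrying a chlorine, or with a phenyl in place of the methyl on the pyrazole.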